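Nitro in place of methyl: compound 3 to compound 4

This account rests on a few compounds, and the source may have more. Where it says the series, first, only, none or still open, it means among the compounds named here.

In an ADME assay on HEK-293T cells (Homo sapiens) for inhibition, read by CCK-8 assay, with a stated time of 48 h, tested at 20 uM (on this read-out higher numbers stand for more inhibition of growth at the one concentration tested and lower numbers for less inhibition of growth), compound 3 (`Cc1ccc(S(=O)(=O)Oc2ccccc2/C=C(\C#N)C(=O)Nc2nnc(Cc3ccc(F)cc3)s2)cc1`) gives 16% inhibition. Compound 1 (`N#C/C(=C\c1ccccc1OS(=O)(=O)c1ccc([N+](=O)[O-])cc1)C(=O)Nc1nnc(Cc2cccc3ccccc23)s1`) gives 25% inhibition, within the scatter of compound 3. Compound 2 (`N#C/C(=C\c1ccccc1OS(=O)(=O)c1ccc([N+](=O)[O-])cc1)C(=O)Nc1nnc(Cc2ccccc2)s1`) is reported as "not toxic" (no number reported) with no number given. Compound 4 (`N#C/C(=C\c1ccccc1OS(=O)(=O)c1ccc([N+](=O)[O-])cc1)C(=O)Nc1nnc(Cc2ccc(F)cc2)s1`) differs from compound 3 by nitro in place of methyl on an aromatic carbon. For the measured compounds named here, no measured pair shows this change alone. Going by the values given here, compound 1 also carries (4-nitrophenyl)sulfonyl and gives 25% inhibition, which offers the only guide. In this assay the expected a number 4 percentage points higher from compound 3 to compound 4 (within the scatter) stays within the scatter, so no clear direction is expected. Compound 4 is estimated at 20% (expected range 8% to 36%).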

Compound 4, percent growth inhibition at one concentration: 8%
Compound 4: the middle estimate sits 12 percentage points above what was measured, and the stated range covers the measured number.
By their numbers in this assay, from the lowest: compounds 4, 3 and 1 (each within the scatter of the next, the first and the last beyond it).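

In this assay, the step with nitro in place of methyl on an aromatic carbon, a number 8 percentage points lower from compound 3 to compound 4 (within the scatter), gives no readable difference at this position. With the (4-nitrophenyl)sulfonyl held in common, 4-fluorophenyl in place of naphthalen-1-yl gives a number 17 percentage points lower from compound 1 to compound 4 (beyond the scatter), a modest step and the only one here beyond the scatter. No measurement offered here accounts for either step.

From the compounds shown here alone, whether an amine or a carboxylic acid in place of nitro would read differently remains open. So does the effect of a longer chain on the saturated carbon carrying the 4-fluorophenyl.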